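A few compounds are considered here, and "the series" means these few. Any claim that something is new, unique, unknown or untested is made for them only; others in the source may bear on it.

Working notes on the series. In an assay on isolated protein for binding affinity to Equilibrative nucleoside transporter 1 (Homo sapiens) (on this read-out higher numbers stand for weaker inhibition and lower numbers for stronger inhibition), compound 1 `OC[C@H]1O[C@@H](n2cnc3c(SC4CCCCC4)ncnc32)[C@H](O)[C@@H]1O` gives 6310 nM, which places it second highest of the three numbers in hand: compound 2 `Nc1nc(SCc2ccc(Br)cc2)c2ncn([C@@H]3O[C@H](CO)[C@@H](O)[C@H]3O)c2n1` gives 813 nM, a lower number beyond the scatter, and compound 3 `OC[C@H]1O[C@@H](n2cc(I)c3c(Cl)ncnc32)[C@H](O)[C@@H]1O` gives 77600 nM, a higher number beyond the scatter. Compound 4 `OC[C@H]1O[C@@H](n2cnc3c(CSc4ccccc4Cl)ncnc32)[C@H](O)[C@@H]1O` differs from compound 1 in one place: ((2-chlorophenyl)sulfanyl)methyl in place of cyclohexylsulfanyl on an aromatic carbon. Within the data shown here, no measured pair tracks this exact change, so the step can only be estimated. The expected step of a 2.1-fold lower number from compound 1 to compound 4 (0.32 log units; beyond the scatter) is a modest move toward a lower number, leaning on compound 2 with 813 nM, which also carries an aromatic ring on a sulfur-linked side chain. Compound 4 is expected to give about 3000 nM, within a range of 500 nM to 20000 nM.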

Compound 4, half-maximal inhibitory concentration: 1780 nM
The estimate for compound 4 lay 1.7-fold (0.23 log units) above the measured number, and the stated range covers the measured number.
By their numbers in this assay, from the lowest: compound 2; then compound 4; then compound 1; then compound 3.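

The swap of cyclohexylsulfanyl for ((2-chlorophenyl)sulfanyl)methyl on this aromatic carbon gives a 3.5-fold lower number from compound 1 to compound 4 (0.55 log units; beyond the scatter) and shows that this position accepts an aromatic ring in place of a non-aromatic one with no loss of inhibition. The change alters the ring, the chlorine and the link to the core together, so the step cannot be assigned to any one of them. Open, on these data alone, is how much of the step belongs to the chlorine, and whether an amine link at this carbon would hold it. Nothing in hand gives a reason for this step.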